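A few compounds are considered here, and "the series" means these few. Any claim that something is new, unique, unknown or untested is made for them only; others in the source may bear on it.

All three measured compounds were tested in an ADME assay on cells (Mus musculus, strain BALB/c) for cytotoxicity, read by MTT assay, with a stated time of 24 h; a higher number here means that more compound is tolerated, a lower number that less compound is tolerated:

Compound 1, `COc1cc(-c2nnc(SCc3ccccc3[N+](=O)[O-])o2)ccc1O`, gives 331000 nM.
Compound 2, `COc1cc(-c2nnc(SCc3ccccc3F)o2)ccc1O`, gives 474000 nM.
Compound 3, `COc1cc(-c2nnc(SCc3ccc(F)cc3F)o2)ccc1O`, gives 520000 nM.

These three compounds share a core and differ only in the groups on the outer benzene ring. Among the measured compounds shown here, compound 2 cannot be set apart from the others: the step of a 1.4-fold higher number from compound 1 to compound 2 (0.16 log units; within the scatter) and the step of a 1.1-fold higher number from compound 2 to compound 3 (0.04 log units; within the scatter) are both within the scatter, so the three numbers read as one level of tolerance, with no compound standing out.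

Compound 4, `COc1cc(-c2nnc(SCc3ccccc3Cl)o2)ccc1O`, has not yet been measured. It differs from compound 2 in one place: chloro in place of fluoro on an aromatic carbon. The two measured steps bear on this change in so far as they also swap one small group for another on the same ring, and neither of them moved the number beyond the scatter. On that basis, no change beyond the scatter is expected for compound 4 either, in either direction, and the step of a 1.1-fold lower number from compound 2 to compound 4 (0.02 log units; within the scatter) is an expectation of no real movement. Compound 4 is therefore estimated to give 450000 nM, within a range from 280000 nM to 720000 nM.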

Compound 4, half-maximal cytotoxic concentration: 564000 nM
Estimate against measurement, compound 4: 1.3-fold (0.10 log units) below, and the stated range covers the measured number.
By their numbers in this assay, from the lowest: compounds 1, 2, 3 and 4 (each within the scatter of the next).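

In this assay the change from the 2-fluorophenyl to the 2-chlorophenyl group, on an aromatic carbon ortho to a large group, gives a 1.2-fold higher number from compound 2 to compound 4 (0.08 log units; within the scatter) and so does not shift the tolerance of these cells. The earlier compounds shown here showed only fluoro and nitro at this position, and chloro now joins them at one level: the comparison with the nitro compound gives a 1.7-fold higher number from compound 1 to compound 4 (0.23 log units; within the scatter) and the comparison with the 2,4-difluorophenyl compound gives a 1.1-fold higher number from compound 3 to compound 4 (0.04 log units; within the scatter) and neither step can be told from repeat-measurement noise. Nothing measured here offers a reason why this position tolerates such different groups equally.

On these data alone, all four compounds keep a single small group or halogen pair on the outer benzene ring, so it remains open whether an amine or a carboxylic acid on the same aromatic carbon would move the number beyond the scatter. As far as these compounds go, it also remains open whether a longer chain in place of the single saturated carbon bound to the sulfur would leave the tolerance at this same level.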